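Taking the formyl group off compound 2

The compounds below may be only part of what the source reports. "The series", "measured", "known", "first", "only" and "open" are said of these compounds alone.

Measured in a functional assay on NPC-TW01 cells (Homo sapiens) for inhibition, read by MTT assay, with a stated time of 72 h; on this read-out lower numbers stand for stronger inhibition of growth and higher numbers for weaker inhibition of growth:
Compound 1 `Cc1ccc(-c2cc(N)n(-c3cccc(Cl)c3)n2)cc1`: > 100000 nM, a limit of the assay and not a number
Compound 2 `Cc1ccc(-c2nn(-c3cccc(Cl)c3)c(/N=C/N(C)C)c2C=O)cc1`: 7200 nM

Among the compounds with values here, compound 2 holds the only true number so far, since the other result is a limit. Compound 3 `Cc1ccc(-c2cc(/N=C/N(C)C)n(-c3cccc(Cl)c3)n2)cc1` has not yet been measured. It differs from compound 2 by one change, hydrogen in place of formyl on an aromatic carbon.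

Within the data shown here, no measured pair isolates this change, so only the two results can guide an expectation. Compound 1 also has hydrogen on that carbon and gives > 100000 nM, which is a limit. Compound 2 carries formyl there and gives 7200 nM. In this assay, weaker growth inhibition beyond the scatter is therefore expected, and compound 3 may reach the limit. The expected size of the change is a 4.2-fold higher number from compound 2 to compound 3 (0.62 log units; beyond the scatter). For compound 3 the estimated value is 30000 nM, within an expected range of 8000 nM to 100000 nM.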

Compound 3, concentration for 50% growth inhibition: > 100000 nM
Compound 3 ended at the assay's limit (the forecaster's own chance of this, stated with the estimate: 35%); middle value at least 3.3-fold (0.52 log units) from the limit.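

In this assay, within the data shown here, this is the first pair of compounds that isolates the formyl group on this aromatic carbon: hydrogen in its place gives an at least 13-fold higher number from compound 2 to compound 3 (1.14 log units; beyond the scatter). The group of 5 heavy atoms is present in both compounds, so that group alone does not give a measurable value here; a measurable value appears only when the formyl group is present as well. The true size of this step stays open, and the step from compound 1 to compound 3 cannot be read at all, because these results are limits of the assay and not numbers: the limit of > 100000 nM in this assay, at which 2 of the 3 values shown sit.

The compounds shown leave open whether a nitrile, an acetyl group or a carboxylic acid on this carbon would serve as formyl does. They also leave open how a compound would behave with formyl on this carbon and a plain amine in place of the group of 5 heavy atoms.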